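Ring-opened amine analogue of compound 2 in brain binding

The source may report more compounds than this note shows. Statements on the series, on what has been measured and on what is new or still open speak of the compounds shown alone.

Measured so far:
compound 1 `CC[C@]1(c2cccs2)OC[C@H]([C@@H]2CCCCN2)O1` gives 205 nM
compound 2 `CN1CCCC[C@H]1[C@H]1COC(c2ccccc2)(c2ccccc2)O1` gives 4400 nM
compound 3 `c1ccc(CN2CCCC[C@H]2[C@H]2COC(c3ccccc3)(c3ccccc3)O2)cc1` gives 10100 nM

In a functional assay (brain) for displacement of a labelled ligand, with Rattus norvegicus as the target (a lower number here means a stronger inhibitor, a higher number a weaker inhibitor), compound 2 stands second highest of the three numbers, with compound 3 nearest and compound 1 furthest, the latter giving the lower number. For the measured compounds named here, the only single-place step on record is a 2.3-fold higher number from compound 2 to compound 3 (0.36 log units; beyond the scatter), which concerns the substituent on the ring amine nitrogen and not the ring itself.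

Compound 4 `CCN[C@@H](C)[C@H]1COC(c2ccccc2)(c2ccccc2)O1` differs from compound 2 as follows: 1-(ethylamino)ethyl in place of 1-methylpiperidin-2-yl on a saturated ring carbon. Going by the values given here, no measured pair isolates this change. Compound 1 carries a hydrogen-bond donor on its amine and gives the lowest number, but it differs from compound 2 in several places at once, so it is not a step. Among the compounds with values here, the change from compound 2 to compound 4 therefore has no direct precedent; the amine remains, a donor is gained, the ring is lost.

On that basis a modest shift toward a lower number is expected for compound 4, a 1.5-fold lower number from compound 2 to compound 4 (0.17 log units; within the scatter), with wide uncertainty in both directions. The estimate for compound 4 is 3000 nM, with a range from 800 nM to 12000 nM.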

Compound 4, inhibition constant: 9000 nM
The estimate for compound 4 lay 3.0-fold (0.48 log units) below the measured number; measured number inside the range.
By their numbers in this assay, from the lowest: compound 1; then compound 2; then compounds 4 and 3 (each within the scatter of the next).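

In this assay, for the compounds shown here, 1-(ethylamino)ethyl in place of 1-methylpiperidin-2-yl on a saturated ring carbon gives a 2.0-fold higher number from compound 2 to compound 4 (0.31 log units; beyond the scatter); this is the first reading of a change at this position, as the earlier step, a 2.3-fold higher number from compound 2 to compound 3 (0.36 log units; beyond the scatter), concerns the substituent on the ring amine nitrogen. The new group has no ring, fewer heavy atoms and a hydrogen-bond donor, yet this combined change gives a higher number, so the gain of the donor does not bring a lower number in this pair, and the pair cannot divide the step among these differences. Nothing at hand accounts for the step, and its cause stays unassigned.

Open, going by these compounds, is how 1-(dimethylamino)ethyl, an open-chain tertiary amine, would stand against compound 2 and compound 4, a comparison that would separate the loss of the ring from the gain of the donor. Also open, on these data alone, is whether a longer chain on the amine, such as 1-(propylamino)ethyl, would move the number in either direction from that of compound 4.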